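The source may hold more compounds than are shown below. What is called first, only, known or untested is meant among the compounds shown, and "the series" means these compounds.

Of the compounds shown here, three built on one shared core have been measured. Compound 1 `COc1ncc(-c2ccc3ncnc(Nc4cnn(CCC(=O)O)c4)c3c2)cc1NS(C)(=O)=O` gives 560 nM in a functional assay on MCF7 cells (Homo sapiens) for antiproliferative activity, read by sulforhodamine B assay, with a stated time of 72 h; on this read-out lower numbers stand for stronger inhibition and higher numbers for weaker inhibition. Compound 2 `COc1ncc(-c2ccc3ncnc(Nc4cnn(CCCO)c4)c3c2)cc1NS(=O)(=O)c1ccc(F)cc1F` gives 1310 nM in this assay. Compound 3 `COc1ncc(-c2ccc3ncnc(Nc4cnn(CCCO)c4)c3c2)cc1NS(C)(=O)=O` gives 730 nM in this assay; its number lies close to both neighbours, with compound 1 the nearer and compound 2 the further, and neither gap reaches beyond the usual scatter. The two single-point steps among them are small: a 1.3-fold higher number from compound 1 to compound 3 (0.12 log units; within the scatter) and a 1.8-fold lower number from compound 2 to compound 3 (0.25 log units; within the scatter).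

Compound 4 `COC(=O)CCn1cc(Nc2ncnc3ccc(-c4cnc(OC)c(NS(C)(=O)=O)c4)cc23)cn1` has not yet been measured. It differs from compound 3 in one place: methoxycarbonyl in place of hydroxymethyl on a saturated chain carbon, two bonds along the chain from an aromatic nitrogen. The step from compound 1 to compound 3 touched this same chain carbon and stayed within the scatter, which suggests that groups at this position have little influence on the read-out so far; the step from compound 2 to compound 3 concerns another part of the molecule and bears less on the question. In this assay compound 4 is therefore expected to show no step beyond the scatter, a 1.0-fold higher number from compound 3 to compound 4 (0.01 log units; within the scatter). The estimate for compound 4 is 750 nM, with a range from 300 nM to 1900 nM.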

Compound 4, half-maximal inhibitory concentration: 490 nM
Compound 4: the middle estimate sits 1.5-fold (0.18 log units) above what was measured; the range from low to high includes it.
By their numbers in this assay, from the lowest: compounds 4, 1, 3 and 2 (each within the scatter of the next, the first and the last beyond it).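

In this assay, methoxycarbonyl in place of hydroxymethyl gives a 1.5-fold lower number from compound 3 to compound 4 (0.17 log units; within the scatter), so a group of 4 heavy atoms with 0 hydrogen-bond donors can replace one of 2 heavy atoms with 1 donor at this chain end without a step beyond the scatter. Methyl in place of hydrogen on the oxygen next to the carbonyl group gives a 1.1-fold lower number from compound 1 to compound 4 (0.06 log units; within the scatter), so the carboxy group of compound 1 and its methoxycarbonyl counterpart also cannot be told apart here, and the three chain ends shown all read alike. Nothing available here explains why these numbers lie so close together.

Going by these compounds, whether an amine or a primary amide at this chain end, or a longer chain, would give a step beyond the scatter remains open. On these data alone, it is also open whether methoxycarbonyl would behave the same way with 2,4-difluorophenyl in place of methyl on the sulfonyl sulfur.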